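A few compounds are considered here, and "the series" means these few. Any claim that something is new, unique, unknown or untested is made for them only; others in the source may bear on it.

Measured so far:
- compound 1, `CC(Sc1nc2c(cnn2C)c(=O)n1-c1ccccc1)c1cccc(F)c1`: 128 nM
- compound 2, `Cn1ncc2c(=O)n(-c3ccccc3)c(OCc3cccc(F)c3)nc21`: 1700 nM
- compound 3, `CC(Sc1nc2nn(C3COC3)cc2c(=O)n1-c1ccccc1)c1ccccn1`: 480 nM

In an assay on isolated protein for inhibition of Retinaldehyde dehydrogenase 3 (Homo sapiens) (on this read-out lower numbers stand for stronger inhibition and higher numbers for weaker inhibition), compound 1 gives the lowest number of the three; compound 3 stands well beyond the scatter above it, and compound 2 further still. The next compound, compound 4 `CC(Sc1nc2c(cnn2C)c(=O)n1-c1ccccc1)c1cccnc1`, keeps the core and the methyl on the ring nitrogen of compound 1 and changes only the aromatic group on the chain carbon: pyridin-3-yl in place of 3-fluorophenyl on a saturated chain carbon bound to a saturated chain carbon and a sulfur. Within the data shown here, no measured pair shows this exact change, so any expectation rests on analogy. Compound 3 carries a pyridin-2-yl there, with a different group on the ring nitrogen, and gives 480 nM, a weaker number than compound 1. A moderate weakening is therefore expected, a 2.5-fold higher number from compound 1 to compound 4 (0.40 log units; beyond the scatter). Compound 4 is estimated at 320 nM, within a range of 110 nM to 950 nM.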

Compound 4, half-maximal inhibitory concentration: 95 nM
The estimate for compound 4 lay 3.4-fold (0.53 log units) above the measured number, outside the stated range (below it).
By their numbers in this assay, from the lowest: compounds 4 and 1 (each within the scatter of the next); then compound 3; then compound 2.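

In this assay the first step read at this position, pyridin-3-yl in place of 3-fluorophenyl on a saturated chain carbon bound to a saturated chain carbon and a sulfur, is small (a 1.3-fold lower number from compound 1 to compound 4 (0.13 log units; within the scatter)) and lies within the scatter. With the core and ring-nitrogen methyl of compound 1 kept, the two aromatic groups cannot be told apart here, although pyridin-3-yl brings a hydrogen-bond acceptor that 3-fluorophenyl lacks. Nothing available accounts for this result.

The compounds shown leave open whether pyridin-3-yl still matches 3-fluorophenyl when it carries an amine or a carboxylic acid. They also leave open how a longer chain in place of the 1-(pyridin-3-yl)ethyl group would read.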